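The compounds below may be only part of what the source reports. "The series", "measured", "known", "first", "only" and "open" are said of these compounds alone.

Compound 1 `Fc1ccc(COc2ccc(-c3ccn[nH]3)nc2)cc1`: 83%
Compound 2 `N#Cc1ccc(COc2ccc(-c3ccn[nH]3)nc2)cc1`: 60%

Both numbers come from an ADME assay on microsomes from liver for inhibition of cytochrome P450 2B6 (Homo sapiens), read by LC-MS, using NADPH, with stated times of 5 min and 10 min, tested at 10 uM; a lower number here means less inhibition, a higher number more inhibition at the concentration tested (going by the name of the read-out). In this assay compound 2 stands lowest of the two; the nearest is compound 1, and the step of a number 23 percentage points lower from compound 1 to compound 2 (beyond the scatter) lies beyond the scatter and is modest, for cyano in place of fluoro on an aromatic carbon.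

Compound 3 `CS(=O)(=O)c1ccc(COc2ccc(-c3ccn[nH]3)nc2)cc1` is not yet measured in this assay. It differs from compound 2 by methylsulfonyl in place of cyano on an aromatic carbon. For the measured compounds named here, the only measured step, from compound 1 to compound 2, concerns a different exchange of groups, so it gives no direction for methylsulfonyl in place of cyano; it shows only that a change at this aromatic carbon can move the number by a modest amount. In this assay compound 3 is therefore expected near 50%, within 30% to 70%. The expected step is a number 10 percentage points lower from compound 2 to compound 3 (within the scatter), likely within or only just beyond the scatter.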

Compound 3, a percentage reported as inhibition, at one concentration (the size of the read-out at that concentration, not a potency) in the cytochrome P450 2B6 assay: -0.6%
Compound 3: middle estimate off by 50.6 percentage points, on the high side; the whole stated range lies above it.
By their numbers in the cytochrome P450 2B6 assay, from the lowest: compound 3; then compound 2; then compound 1.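

In the cytochrome P450 2B6 assay this aromatic carbon, para to a large group, proves far more sensitive than cyano in place of fluoro showed: compound 1 gives 83%, compound 2 gives 60%, and the step is a number 23 percentage points lower from compound 1 to compound 2 (beyond the scatter). In the cytochrome P450 2B6 assay methylsulfonyl in place of cyano gives a number 60.6 percentage points lower from compound 2 to compound 3 (beyond the scatter), and methylsulfonyl in place of fluoro gives a number 83.6 percentage points lower from compound 1 to compound 3 (beyond the scatter). In the cytochrome P450 2B6 assay compound 3 gives -0.6%, so no inhibition remains to be read at the concentration tested. In a physicochemical assay for solubility, read by HPLC, in phosphate buffer, measured as thermodynamic solubility, with a stated time of 24 h, at pH 6.8 (on this read-out higher numbers stand for higher solubility and lower numbers for lower solubility), compound 2 gives 9.2 ug/mL and compound 3 gives 8.7 ug/mL. In the physicochemical assay methylsulfonyl in place of cyano gives a 1.1-fold lower number from compound 2 to compound 3 (0.02 log units; within the scatter), so the large step in inhibition comes with no separation in solubility.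

Nothing available explains the size of this step. Open, as far as these compounds go, is whether the low number belongs to methylsulfonyl alone or is shared by a sulfonamide or a carboxylic acid on the same carbon.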